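Benzamide series in HeLa growth inhibition: outlook for compound 4

A few compounds are considered here, and "the series" means these few. Any claim that something is new, unique, unknown or untested is made for them only; others in the source may bear on it.

Measured so far in a functional assay on HeLa cells (Homo sapiens) for inhibition, read by CCK-8 assay, with a stated time of 72 h, tested at 2 uM; a lower number here means less inhibition of growth, a higher number more inhibition of growth at the concentration tested:
compound 1 `Nc1ccccc1NC(=O)c1ccc(CSc2ccc(Br)cc2)cc1` gives 18.8%
compound 2 `Cc1cc(C)cc(SCc2ccc(/C=C/C(=O)Nc3ccccc3N)cc2)c1` gives 11.7%
compound 3 `COc1ccc(SCc2ccc(C(=O)Nc3ccccc3N)cc2)cc1OC` gives 15.2%

The three numbers sit close together. The gap from compound 2 to compound 3 and the gap from compound 2 to compound 1 are both within the usual scatter of repeated measurements, so none of the three can be set apart from the others in this assay; compound 2 stands among them, not outside them. No pair of these compounds differs in only one place, so no single structural step has yet been read against a change in the number.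

Compound 4 `CCc1ccc(SCc2ccc(/C=C/C(=O)Nc3ccccc3N)cc2)cc1` has not yet been measured. It is the companion of compound 2 with the same atoms joined differently:

4-ethylphenyl in place of 3,5-dimethylphenyl on a sulfur

The group that leaves and the group that enters are both a six-membered aromatic ring of carbon only, each with eight heavy atoms, neither carrying a donor nor an acceptor. Among the compounds with values here, nothing in the three numbers so far ties a change on the sulfur to a shift in this assay, and the whole set lies within one band of scatter. The expected step from compound 2 to compound 4 is a number 2.3 percentage points higher from compound 2 to compound 4 (within the scatter), that is, none beyond the scatter in either direction. Compound 4 is therefore estimated at 14% in this assay, with a range from 5% to 28%.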

Compound 4, percent growth inhibition at one concentration: 3.96%
Estimate against measurement, compound 4: 10 percentage points above; measured number below the stated range.
By their numbers in this assay, from the lowest: compounds 4, 2, 3 and 1 (each within the scatter of the next, the first and the last beyond it).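

Within the data shown here, this is the first pair that differs in one place, and so the first change on the sulfur that can be read: in this assay 4-ethylphenyl in place of 3,5-dimethylphenyl gives a number 7.7 percentage points lower from compound 2 to compound 4 (within the scatter) and the two compounds cannot be set apart. For this one pair, rearranging the alkyl carbons from two methyl groups to one ethyl group on the aromatic ring, with the same atoms overall and the ring kept, does not produce a step that can be told from repeat scatter at the single concentration tested. No measurement at hand bears on what might lie behind this step.

Compound 2 and compound 4 share one core, and whether the same exchange reads alike on the core of compound 1 stays open, as no pair shown tests it. Also open, from the compounds shown here alone, is whether in this assay a group of another kind on the sulfur, such as a carboxylic acid, an amine or a longer saturated carbon chain in place of the aromatic ring, would give a step beyond the scatter.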